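The compounds below may be only part of what the source reports. "The series", "measured", "known", "first", "only" and "open" are said of these compounds alone.

Compound 1 `CCOc1ccc2c(=O)c(-c3ccc(O)cc3)coc2c1` gives 95.6% in a functional assay on mitochondria (Cricetulus griseus) for inhibition of Monoamine oxidase (Homo sapiens), tested at 3 uM; on this read-out higher numbers stand for a stronger effect at the one concentration tested and lower numbers for a weaker effect. Compound 2 `O=c1c(-c2ccc(O)cc2)coc2cc(OCCCCCCBr)ccc12` gives 88.5% in this assay and thus stands at the lower end of the two numbers, with compound 1 its nearest neighbour; the step of a number 7.1 percentage points lower from compound 1 to compound 2 (within the scatter) lies within the scatter. Compound 3 `O=c1c(-c2ccc(O)cc2)coc2cc(OCCCCBr)ccc12` differs from compound 2 by bromo in place of 2-bromoethyl on a saturated chain carbon, four bonds along the chain from an oxygen on an aromatic ring. Within the data shown here, the one step on record, a number 7.1 percentage points lower from compound 1 to compound 2 (within the scatter), also altered the length of this chain and stayed within the scatter, so no movement beyond the scatter is anticipated here. Compound 3 is expected to give 89% in this assay, estimated between 78% and 97%. The expected step is a number 0.5 percentage points higher from compound 2 to compound 3 (within the scatter).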

Compound 3, a percentage reported as inhibition, at one concentration (the size of the read-out at that concentration, not a potency): 84.7%
Compound 3: middle estimate off by 4.3 percentage points, on the high side; the measured number falls inside the stated range.
By their numbers in this assay, from the lowest: compounds 3, 2 and 1 (each within the scatter of the next, the first and the last beyond it).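

In this assay, with the change at the saturated chain carbon four bonds along the chain from an oxygen on an aromatic ring, bromo in place of 2-bromoethyl gives a number 3.8 percentage points lower from compound 2 to compound 3 (within the scatter) and so does not separate the two compounds. Among these compounds, measured against compound 1, 2-bromoethyl in place of hydrogen gives a number 10.9 percentage points lower from compound 1 to compound 3 (beyond the scatter) as the first modest step, whereas the step to compound 2 stayed within the scatter. No available evidence bears on these numbers.

As far as these compounds go, whether an amine or a carboxylic acid in place of bromo would hold the read-out stays open, as does the effect of a chain longer than that of compound 2.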